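Removing one ring substituent on the shared core

The compounds below may be only part of what the source reports. "The series", "measured", "known", "first", "only" and "open" are said of these compounds alone.

Measured compounds:
compound 1 `FC(F)(F)c1ccc(Nc2ncnc3sc(Nc4c(Cl)cccc4Cl)nc23)cc1`, 3 nM
compound 2 `Cc1cccc(C)c1Nc1nc2c(Nc3ccc(C(F)(F)F)cc3)ncnc2s1`, 6 nM

Both compounds were tested in a functional assay on HEK293 cells for antagonist activity at transient receptor potential cation channel subfamily V member 1 (Rattus norvegicus), read by calcium flux; on this read-out lower numbers stand for stronger inhibition and higher numbers for weaker inhibition. Compound 1 gives 3 nM and compound 2 gives 6 nM. The step of a 2.0-fold higher number from compound 1 to compound 2 (0.30 log units; within the scatter) shows that swapping the two chlorines for two methyl groups changed little. Compound 2 therefore holds the higher of the two numbers, but its gap to compound 1 is within the scatter, so the two cannot be ranked.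

Compound 3 `FC(F)(F)c1ccc(Nc2ncnc3sc(Nc4ccccc4Cl)nc23)cc1` is not yet measured. It differs from compound 2 as follows: 2-chlorophenyl in place of 2,6-dimethylphenyl on a nitrogen on an aromatic ring. Going by the values given here, only one measured step bears on this change, namely a 2.0-fold higher number from compound 1 to compound 2 (0.30 log units; within the scatter), and it concerns exchanging two substituents rather than dropping one, so it speaks only indirectly. Among the compounds with values here, no measured pair shows what losing a second ring substituent does. Given that chlorine and methyl gave near-equal numbers, compound 3 is expected to stay close to compound 2, with at most a modest move toward a higher number, an estimated step of a 1.3-fold higher number from compound 2 to compound 3 (0.12 log units; within the scatter). Compound 3 is thus estimated at 8 nM, within the range 3 nM to 25 nM.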

Compound 3, half-maximal inhibitory concentration: 32 nM
The estimate for compound 3 lay 4.0-fold (0.60 log units) below the measured number; the whole stated range lies below it.
By their numbers in this assay, from the lowest: compounds 1 and 2 (each within the scatter of the next); then compound 3.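

The second substituent on this ring turns out to matter: in this assay, putting hydrogen in place of chloro on an aromatic carbon gives an 11-fold higher number from compound 1 to compound 3 (1.03 log units; beyond the scatter), a large weakening of inhibition from a single-atom change. The step of a 5.3-fold higher number from compound 2 to compound 3 (0.73 log units; beyond the scatter), in which 2-chlorophenyl replaces 2,6-dimethylphenyl, also lies beyond the scatter, whereas the earlier exchange of chlorines for methyl groups, a 2.0-fold higher number from compound 1 to compound 2 (0.30 log units; within the scatter), did not. Across these three compounds, then, keeping both substituents on the ring counted for more than whether they were chlorine or methyl, and neither of the groups that carry both goes against this; no measurement shown here explains why the loss of one substituent has this effect.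

The compounds shown leave open whether the remaining chlorine of the 2-chlorophenyl group does anything by itself, since an unsubstituted phenyl ring on this nitrogen would be needed to tell. They also leave open whether a single methyl group, or a methoxy group or nitrile, in place of that chlorine would give a number like that of compound 3 or a different one.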